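Compound 1 to compound 4: one group exchanged

The compounds below may be only part of what the source reports. "The series", "measured", "known", "first", "only" and "open" are said of these compounds alone.

compound 1 `CCCC(Oc1ccc(-n2cc(OC)cn2)cc1)c1ccc(C(=O)NCCC(=O)O)cc1`: 1.4
compound 2 `CCCC(Nc1ccc(-n2cc(C(F)(F)F)cn2)nc1)c1ccc(C(=O)NCCC(=O)O)cc1`: 2.1
compound 3 `O=C(O)CCNC(=O)c1ccc(C(Oc2ccc(-n3cc(C(F)(F)F)cn3)cc2)C2CC2)cc1`: 1.7

Of the compounds shown here, three have so far been measured in a physicochemical assay for lipophilicity, using the shake flask method, at pH 7.4; a lower number here means a more polar compound, a higher number a more lipophilic compound. Compound 1 stands at 1.4, and compound 3 at 1.7 lies within the scatter of it, so these two cannot be told apart. Compound 2 at 2.1 lies beyond the scatter from compound 1, on the higher side. Among the measured compounds shown here, no two measured compounds differ in one place only, so no single exchange has yet been seen on its own.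

Compound 4 `CCCC(Oc1ccc(-n2cc3ccccc3n2)cc1)c1ccc(C(=O)NCCC(=O)O)cc1` keeps the core of compound 1 and alters one group: 2H-indazol-2-yl in place of 4-methoxy-1H-pyrazol-1-yl on an aromatic carbon. In words, 2H-indazol-2-yl stands in place of 4-methoxy-1H-pyrazol-1-yl on an aromatic carbon, para to a large group. For the measured compounds named here, with no measured step at that place, the expectation rests on the structural change and on the spread of the three numbers. Compound 2 at 2.1 shows how far above compound 1 this small set already reaches. An upward move beyond the scatter is expected in this assay, estimated as a number 0.70 log units higher from compound 1 to compound 4 (beyond the scatter). For compound 4 the estimated value is 2.1, with an expected range from 1.7 to 2.5.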

Compound 4, distribution coefficient: 2.5
For compound 4 the middle estimate is 0.40 log units below the measured one; the measured number falls inside the stated range.
By their numbers in this assay, from the lowest: compounds 1 and 3 (each within the scatter of the next); then compound 2; then compound 4.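

In this assay, among the compounds shown here, 2H-indazol-2-yl in place of 4-methoxy-1H-pyrazol-1-yl on an aromatic carbon, para to a large group, gives a number 1.10 log units higher from compound 1 to compound 4 (beyond the scatter) as the first single exchange in this set that can be read on its own. It shows that the number at this position can move well beyond the scatter with a change of this one group, which the three earlier compounds, differing from each other in more than one place, could not show. No measurement shown here bears on why the number rises.

The exchange adds a six-membered aromatic ring of carbon only and also removes the methoxy group, and this one step leaves open which of the two changes accounts for the rise, a question that a plain 1H-pyrazol-1-yl or a 4-methyl-1H-pyrazol-1-yl group at this place would bear on. From the compounds shown here alone, whether 2H-indazol-2-yl would give a step of similar size on the core of compound 2 or the core of compound 3 also stays open.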